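The compounds below may be only part of what the source reports. "The series", "measured", "known", "first", "only" and "open" are said of these compounds alone.

Measured compounds in an ADME assay on HepG2 cells (Homo sapiens) for cytotoxicity, read by luminescence, CellTiter-Glo and ATP content, with a stated time of 72 h; a higher number here means that more compound is needed for the effect, a lower number that less compound is needed:

compound 1 `c1ccc(Oc2ccc3c(NCCCNCc4ccco4)ccnc3c2)cc1`: 15200 nM
compound 2 `COc1cccc(CNCCCNc2ccnc3cc(Oc4ccc(Cl)cc4)ccc23)c1O`: 5700 nM
compound 3 `COc1cccc(CNCCCNc2ccnc3cc(Oc4ccccc4)ccc23)c1O`: 6800 nM

Compound 3 stands second highest of the three numbers in this assay. Its nearest neighbour is compound 2: the step of a 1.2-fold higher number from compound 2 to compound 3 (0.08 log units; within the scatter) lies within the scatter, so the two are not separated. Its furthest is compound 1: the step of a 2.2-fold lower number from compound 1 to compound 3 (0.35 log units; beyond the scatter) is modest but beyond the scatter.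

Compound 4 `COc1cccc(CNCCCNc2ccnc3cc(-c4cccc5ccccc45)ccc23)c1O` is not yet measured. It differs from compound 3 by naphthalen-1-yl in place of phenoxy on an aromatic carbon. Neither measured step touches this position: the step from compound 1 to compound 3 concerns the group on the saturated chain carbon bound to an amine nitrogen, and the step from compound 2 to compound 3 concerns a substituent on a different aromatic carbon. There is therefore no direct guide to the size or direction of the change in this assay, and the expectation is a step within or only modestly beyond the scatter, direction uncertain, a 1.4-fold lower number from compound 3 to compound 4 (0.13 log units; within the scatter). Compound 4 is estimated at 5000 nM, with a range from 1500 nM to 15000 nM.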

Compound 4, half-maximal effective concentration: 2520 nM
Estimate against measurement, compound 4: 2.0-fold (0.30 log units) above; the measured number falls inside the stated range.
By their numbers in this assay, from the lowest: compound 4; then compounds 2 and 3 (each within the scatter of the next); then compound 1.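

Going by these compounds alone, at the aromatic carbon para to a fused ring, in this assay, naphthalen-1-yl in place of phenoxy gives a 2.7-fold lower number from compound 3 to compound 4 (0.43 log units; beyond the scatter), the first step at this position to go beyond the scatter. Starting from the 4-chlorophenoxy group, the same kind of exchange gives a 2.3-fold lower number from compound 2 to compound 4 (0.35 log units; beyond the scatter), so the two aryl ether groups lead to the same reading, while the chloro group alone separated nothing between compound 2 and compound 3. Nothing measured accounts for this shift.

Two things change together here, the oxygen link leaves and a second aromatic ring enters, so the compounds shown cannot tell which of them goes with the lower number; a directly bound phenyl or a naphthalen-1-yloxy group at this position would separate them. On these data alone, whether the step holds with furan-2-yl on the chain also remains open.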